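Series notes: cytotoxicity readings and one estimate

The source may hold more compounds than are shown below. What is called first, only, known or untested is meant among the compounds shown, and "the series" means these compounds.

Measured compounds:
compound 1 `Cc1ccc(-c2cs/c(=N/NC(=O)CSc3nnnn3C)n2-c2ccccc2)cc1` — 243 ug/mL
compound 2 `Cn1nnnc1SCC(=O)N/N=c1/scc(-c2ccc(Cl)cc2)n1-c1ccccc1` — 40 ug/mL
compound 3 `O=C(CSc1ncccn1)N/N=c1/scc(-c2ccc(Cl)cc2)n1-c1ccccc1` — 397 ug/mL

In an ADME assay on NIH3T3 cells (Mus musculus) for cytotoxicity, read by MTT assay, with a stated time of 24 h (on this read-out higher numbers stand for weaker inhibition and lower numbers for stronger inhibition), compound 2 gives 40 ug/mL, the lowest of the three numbers. Compound 3 gives 397 ug/mL and stands highest; compound 1 gives 243 ug/mL, which lies within the scatter of compound 3, so no order is read between those two. Two single changes start from compound 2. The change methyl in place of chloro on an aromatic carbon made a 6.1-fold higher number from compound 2 to compound 1 (0.78 log units; beyond the scatter). The change pyrimidin-2-yl in place of 1-methyl-1H-tetrazol-5-yl on a sulfur made a 9.9-fold higher number from compound 2 to compound 3 (1.00 log units; beyond the scatter). Compound 4 `Cc1ccc(-c2cs/c(=N/NC(=O)CSc3ncccn3)n2-c2ccccc2)cc1` has not been measured; it differs from compound 3 by methyl in place of chloro on an aromatic carbon, the same kind of change as from compound 2 to compound 1, and the place is described in the same words for both pairs. Going by the values given here, only that one earlier pair is available to carry the change across, and the two pairs differ in the group on the sulfur, so the transfer is uncertain. For compound 4 the expected step is a 1.8-fold higher number from compound 3 to compound 4 (0.25 log units; within the scatter), kept smaller than the earlier one because compound 3 starts at 397 ug/mL, already the highest of the three numbers. The estimate for compound 4 is 700 ug/mL, ranging from 250 ug/mL to 1600 ug/mL.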

Compound 4, half-maximal inhibitory concentration: > 500 ug/mL
Compound 4 ended at the assay's limit (the forecaster's own chance of this, stated with the estimate: 35%); the middle value is on the limit's open side.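

In this assay compound 4 gives > 500 ug/mL, which is a limit of the assay and not a number. Methyl in place of chloro on an aromatic carbon makes an at least 1.2-fold higher number from compound 3 to compound 4 (0.10 log units; that floor lies within the scatter), so a step in the same direction as the earlier one is not established on this core, and its size is not fixed either: the same change on two cores in this assay, a 6.1-fold higher number (0.78 log units; beyond the scatter) from compound 2 to compound 1 and an at least 1.2-fold higher number (0.10 log units; that floor lies within the scatter) from compound 3 to compound 4; the limit leaves it open whether they differ Pyrimidin-2-yl in place of 1-methyl-1H-tetrazol-5-yl on a sulfur makes an at least 2.0-fold higher number from compound 1 to compound 4 (0.31 log units; beyond the scatter), so this change keeps its direction on the second core, while the data do not show whether its size carries over: the same change on two cores in this assay, a 9.9-fold higher number (1.00 log units; beyond the scatter) from compound 2 to compound 3 and an at least 2.0-fold higher number (0.31 log units; beyond the scatter) from compound 1 to compound 4; the limit leaves it open whether they differ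

The compounds shown leave open how fluoro or methoxy would read in place of chloro on that aromatic carbon. They also leave open how a phenyl or a pyridin-2-yl would read on the sulfur, so both changes rest on two pairs each, and each has one end at the limit.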